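Swapping Methylsulfanyl for Chloro: Expected Effect on Clearance

The compounds below may be only part of what the source reports. "The series", "measured", "known", "first", "only" and "open" are said of these compounds alone.

Of the compounds shown here, three have been measured in an ADME assay on microsomes from liver (Rattus norvegicus) for metabolic stability; on this read-out higher numbers stand for fast clearance and lower numbers for slow clearance. Compound 1 `CCCC(C#N)(CC)Nc1nc(NC)nc(-n2cncn2)n1` gives 29 mL/min/kg, and compound 2 `C#CC(CC)(CC)Nc1nc(NC)nc(-n2cncn2)n1` gives 22 mL/min/kg. Compound 3 `CNc1nc(NC2(C#N)CCCCC2)nc(SC)n1` gives 579 mL/min/kg, the highest of the three numbers; its nearest neighbour is compound 1, and both compound 1 and compound 2 lie far enough away that the gaps are beyond the usual scatter. Compound 4 `CNc1nc(Cl)nc(NC2(C#N)CCCCC2)n1` is a close relative of compound 3 and has not yet been measured. The change is chloro in place of methylsulfanyl on an aromatic carbon. In this assay the expected change is a 3.9-fold lower number from compound 3 to compound 4 (0.59 log units; beyond the scatter), a drop beyond the scatter, since compound 3 starts from 579 mL/min/kg. For compound 4 the estimate is 150 mL/min/kg, with a range from 50 mL/min/kg to 450 mL/min/kg.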

Compound 4, clearance: 867 mL/min/kg
The estimate for compound 4 lay 5.8-fold (0.76 log units) below the measured number, and the stated range ends below it.
By their numbers in this assay, from the lowest: compounds 2 and 1 (each within the scatter of the next); then compounds 3 and 4 (each within the scatter of the next).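

In this assay chloro in place of methylsulfanyl on this aromatic carbon, opposite the ring nitrogen, gives a 1.5-fold higher number from compound 3 to compound 4 (0.18 log units; within the scatter) and so leaves the two compounds indistinguishable. At this position, with the methylamino group and the group of 9 heavy atoms unchanged, the swap has no effect that this read-out can resolve. Nothing available here offers a reason for this result.

Going by these compounds, whether the two groups would also match on a different core remains open. So does how an amine, a methoxy group or a longer chain would behave at this position.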